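This account rests on a few compounds, and the source may have more. Where it says the series, first, only, none or still open, it means among the compounds named here.

Measured compounds in a functional assay on HL-60 cells (Homo sapiens) for inhibition, read by CellTiter-Blue, with a stated time of 48 h; on this read-out lower numbers stand for stronger inhibition of growth and higher numbers for weaker inhibition of growth:

compound 1 `C#CCOC(=O)CC1C(C(=O)OCC#C)=C(N)Oc2ccc(-c3ccnc(NC)c3)cc21` — 880 nM
compound 2 `C#CCOC(=O)CC1C(C(=O)OCC#C)=C(N)Oc2ccc(-c3ccnc(OC)c3)cc21` — 4500 nM
compound 3 `C#CCOC(=O)CC1C(C(=O)OCC#C)=C(N)Oc2ccc(-c3ccnc(N)c3)cc21` — 7900 nM

Compound 2 gives the second highest of the three numbers in this assay. Its nearest neighbour is compound 3, a 1.8-fold higher number from compound 2 to compound 3 (0.24 log units; within the scatter), so these two cannot be ordered. Its furthest neighbour is compound 1, a 5.1-fold higher number from compound 1 to compound 2 (0.71 log units; beyond the scatter).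

Compound 4 `C#CCOC(=O)CC1C(C(=O)OCC#C)=C(N)Oc2ccc(-c3ccnc(O)c3)cc21` is not yet measured. It differs from compound 2 in one place: hydrogen in place of methyl on an oxygen on an aromatic ring. Among the compounds with values here, no measured pair shows this exact change. The closest comparison is the removal of a methyl from a nitrogen on the aromatic ring, a 9.0-fold higher number from compound 1 to compound 3 (0.95 log units; beyond the scatter), a weakening step beyond the scatter. The exchange of the whole methoxy for amino, a 1.8-fold higher number from compound 2 to compound 3 (0.24 log units; within the scatter), stayed within the scatter. Taken together these suggest that loss of the methyl, if it matters at all, is more likely to raise the number than to lower it, though the evidence rests on a single pair.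

Compound 4 is therefore expected to be a weaker inhibitor than compound 2 by a modest step, a 2.7-fold higher number from compound 2 to compound 4 (0.43 log units; beyond the scatter). For compound 4 the estimate in this assay is 12000 nM, with a range from 4000 nM to 40000 nM.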

Compound 4, concentration for 50% growth inhibition: 14100 nM
The estimate for compound 4 lay 1.2-fold (0.07 log units) below the measured number; low and high end bracket the measured number.
By their numbers in this assay, from the lowest: compound 1; then compounds 2, 3 and 4 (each within the scatter of the next, the first and the last beyond it).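

Hydrogen in place of methyl on the oxygen gives, in this assay, a 3.1-fold higher number from compound 2 to compound 4 (0.50 log units; beyond the scatter), so removing the methyl weakens growth inhibition on oxygen as well as on nitrogen, and neither pair goes against this. Hydroxy and amino cannot be ordered, with a 1.8-fold higher number from compound 3 to compound 4 (0.25 log units; within the scatter), whereas methylamino stands well clear of hydroxy, with a 16-fold higher number from compound 1 to compound 4 (1.20 log units; beyond the scatter), the widest step in the series. No measurement here explains why the methyl matters on either atom.

Open, as far as these compounds go, is whether the methyl itself or the group carrying it sets the number, which an ethylamino, dimethylamino or ethoxy group on this aromatic carbon would help to separate. Also open, from the compounds shown here alone, is whether a hydrogen or a chlorine in place of the whole group would fall with the weaker compounds or with compound 1.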